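The compounds below may be only part of what the source reports. "The series", "measured", "known", "first", "only" and "open" are said of these compounds alone.

Measured in a functional assay on THP-1 cells (Homo sapiens) for cytotoxicity, read by MTT assay, with a stated time of 24 h; on this read-out higher numbers stand for weaker inhibition and lower numbers for stronger inhibition:
- Compound 1 `COc1cc(/C=C2\CN(C)C/C(=C\c3ccccc3F)C2=O)cc(OC)c1OC`: 640 nM
- Compound 2 `CN1C/C(=C\c2cccc([N+](=O)[O-])c2)C(=O)/C(=C/c2ccccc2F)C1`: 1010 nM
- Compound 3 `COc1cc(/C=C2\CN(C)C/C(=C\c3ccc(Cl)cc3Cl)C2=O)cc(OC)c1OC`: 5020 nM

Compound 2 lies within the scatter of compound 1, while compound 3 stands beyond the scatter above both. Compound 4 `CN1C/C(=C\c2cccc([N+](=O)[O-])c2)C(=O)/C(=C/c2ccc(Cl)cc2Cl)C1` has not yet been measured. It carries 2,4-dichlorophenyl in place of the 2-fluorophenyl of compound 2, on a double-bonded chain carbon bound to a double-bonded ring carbon: 2,4-dichlorophenyl in place of 2-fluorophenyl on a double-bonded chain carbon bound to a double-bonded ring carbon. The same exchange has been measured once, in a pair with a different group elsewhere on the shared core, giving a 7.8-fold higher number from compound 1 to compound 3 (0.89 log units; beyond the scatter). That single modest step, beyond the scatter, points to a rise of similar size in this assay. The expected step is a 6.9-fold higher number from compound 2 to compound 4 (0.84 log units; beyond the scatter). For compound 4 the estimate is 7000 nM, with an expected range from 2500 nM to 18000 nM.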

Compound 4, half-maximal inhibitory concentration: 3560 nM
For compound 4 the middle estimate is 2.0-fold (0.29 log units) above the measured one, and the stated range covers the measured number.
By their numbers in this assay, from the lowest: compounds 1 and 2 (each within the scatter of the next); then compounds 4 and 3 (each within the scatter of the next).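

In this assay, 2,4-dichlorophenyl in place of 2-fluorophenyl on a double-bonded chain carbon bound to a double-bonded ring carbon gives a 3.5-fold higher number from compound 2 to compound 4 (0.55 log units; beyond the scatter) and so shows weaker inhibition on a second core, not only on the core of compound 1. The size of the change does not separate the two cores: the same change on two cores in this assay, a 7.8-fold higher number (0.89 log units; beyond the scatter) from compound 1 to compound 3 and a 3.5-fold higher number (0.55 log units; beyond the scatter) from compound 2 to compound 4, 2.2-fold (0.35 log units) apart, within the scatter of two such steps.

The compounds shown do not tell whether a single chlorine on the phenyl ring would give a similar step. As far as these compounds go, how an aminophenyl or carboxyphenyl group would read at this place also remains open.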